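The source may report more compounds than this note shows. Statements on the series, on what has been measured and on what is new or still open speak of the compounds shown alone.

Compound 1 `CC1=CC[C@H](C(C)(C)NC(=S)NN)CC1` is the simplest member of this small group, and in a functional assay on UACC-62 cells (Homo sapiens) for inhibition, read by sulforhodamine B assay, with a stated time of 48 h (a lower number here means a stronger inhibitor of growth, a higher number a weaker inhibitor of growth), compound 1 gives "not determined" (no result reported). Compound 2 `CC1=CC[C@H](C(C)(C)NC(=S)N/N=C/c2ccc(O)cc2)CC1` carries a hydroxy group on an aromatic carbon of the ring that hangs on the carbon with a double bond to nitrogen. In this assay compound 2 gives > 100000 nM, which is a limit of the assay and not a number. Compound 3 `CC1=CC[C@H](C(C)(C)NC(=S)N/N=C/c2ccc(Cl)cc2)CC1` has a 4-chlorophenyl group in that place. In this assay compound 3 gives > 100000 nM, again a limit rather than a number. The step that the two limits leave unreadable from compound 2 to compound 3 therefore cannot be read. Compound 3 thus stands at the limit of > 100000 nM in this assay, at which 2 of the 3 values shown sit, so it cannot be placed above or below compound 2. Compound 4 `CC1=CC[C@H](C(C)(C)NC(=S)N/N=C/c2ccco2)CC1` differs from compound 3 by furan-2-yl in place of 4-chlorophenyl on a carbon with a double bond to nitrogen. Going by the values given here, no measured step resembles this change, and the one measured step between compounds that differ in a single place is unreadable. The expected step of a number no higher from compound 3 to compound 4 (the limit leaves the size open) is accordingly none beyond the scatter, and compound 4 is expected to remain at the limit as well. Compound 4 is estimated at 100000 nM in this assay, with a range from 30000 nM to 300000 nM.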

Compound 4, concentration for total growth inhibition: 14100 nM
The estimate for compound 4 lay 7.1-fold (0.85 log units) above the measured number; measured number outside the range, below it.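

In this assay, the group on a carbon with a double bond to nitrogen proves able to change growth inhibition: the move to furan-2-yl gives an at least 7.0-fold lower number from compound 3 to compound 4 (0.85 log units; beyond the scatter), and an at least 7.0-fold lower number from compound 2 to compound 4 (0.85 log units; beyond the scatter). The earlier pair could not show this, as its step cannot be read, and both new steps are minimum sizes only, since compound 2 and compound 3 each rest at a limit of the assay and not at a number: the limit of > 100000 nM in this assay, at which 2 of the 4 values shown sit. Within these compounds, then, replacing either substituted phenyl group with furan-2-yl, a five-membered aromatic ring with one hetero atom, is the one change that yields a measurable value.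

The compounds shown do not separate the roles of ring size and the ring oxygen, which is the one hydrogen-bond acceptor the entering group adds, so they cannot say which feature of furan-2-yl matters. A thiophen-2-yl or pyridin-2-yl group at this place, or an amine or a carboxylic acid on the furan ring, would be needed to tell how far this gain extends.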